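The source may report more compounds than this note shows. Statements on the series, on what has been measured and on what is new or still open speak of the compounds shown alone.

Working notes on the series. Compound 1 `CCCn1c(=O)[nH]c2nc(-c3ccc(S(=O)(=O)N4CCN(Cc5cccc(C)c5)CC4)cc3)[nH]c2c1=O` and compound 2 `CCCn1c(=O)[nH]c2nc(-c3ccc(S(=O)(=O)N4CCN(C)CC4)cc3)[nH]c2c1=O` share one core and differ at the amine nitrogen in a ring. In an assay on CHO cells for displacement of a labelled ligand from adenosine receptor A3 (Homo sapiens), read by scintillation counting, with a stated time of 45 min, in the presence of a further agent that is not named here (a higher number here means a weaker inhibitor, a lower number a stronger inhibitor), compound 1 gives only a limit, > 1000 nM. In this assay compound 2 likewise gives only a limit, > 1000 nM. The step that the two limits leave unreadable from compound 1 to compound 2 cannot be sized, since both values sit at the limit of > 1000 nM in this assay, at which 2 of the 2 values shown sit. Compound 2 thus stands at the limit of this assay with no number of its own. Among the measured compounds shown here, the one further value shown, that of compound 1, is a limit as well.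

Compound 3 `CCCn1c(=O)[nH]c2nc(-c3ccc(S(=O)(=O)N4CCN(c5cccc(Cl)c5)CC4)cc3)[nH]c2c1=O` is the next member: 3-chlorophenyl in place of methyl on an amine nitrogen in a ring. For the measured compounds named here, the only measured step, a step that the two limits leave unreadable from compound 1 to compound 2, bears on the same nitrogen and was itself unreadable, so it sets neither size nor direction. Going by the values given here, no measured compound has a value inside the readable range of this assay. Among the compounds with values here, for compound 3 the expectation is therefore the limit again, with a step that the limit leaves unreadable from compound 2 to compound 3 meaning no step that can be read beyond the scatter. The estimate for compound 3 in this assay is 5000 nM, within 1500 nM to 30000 nM.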

Compound 3, inhibition constant: 53.5 nM
Compound 3: middle estimate off by 93-fold (1.97 log units), on the high side; the whole stated range lies above it.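

Among the compounds shown here, on the amine nitrogen in a ring, the group decides whether this assay returns a number at all: 3-chlorophenyl in place of methyl gives an at least 18-fold lower number from compound 2 to compound 3 (1.27 log units; beyond the scatter) and the first value of the series inside the readable range. An aromatic ring on this nitrogen is not enough by itself, since compound 1 also carries one in its 3-methylbenzyl group, and replacing that group with 3-chlorophenyl still gives an at least 18-fold lower number from compound 1 to compound 3 (1.27 log units; beyond the scatter) as a large change. Going by these compounds, both steps are measured from a limit and not from a number, so their full size stays unknown, and the steps between the other compounds cannot be read: (the limit of > 1000 nM in this assay, at which 2 of the 3 values shown sit).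

The change from compound 1 to compound 3 removes the saturated chain carbon and exchanges methyl for chlorine in one step, so plain phenyl, 3-methylphenyl or 3-chlorobenzyl on that nitrogen would be needed to separate the two contributions. On these data alone, how 4-chlorophenyl or 3-methoxyphenyl on the same nitrogen would read in this assay also remains open.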